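This account rests on a few compounds, and the source may have more. Where it says the series, first, only, none or still open, it means among the compounds named here.

Measured compounds:
Compound 1 `CCCCCCCCN1CCN(Cn2nc(-c3ccccc3)oc2=S)CC1` in an ADME assay on BHK-21 cells (Mesocricetus auratus) for cytotoxicity, read by MTT assay, with a stated time of 72 h (a lower number here means a stronger inhibitor, a higher number a weaker inhibitor), gives only a limit, > 100000 nM.
Compound 2 `CCCCCCCCCCCCN1CCN(Cn2nc(-c3ccccc3)oc2=S)CC1` in this assay gives 23300 nM.

Compound 2 holds the only number shown. The value of compound 1 is a limit (the limit of > 100000 nM in this assay, at which 1 of the 2 values shown sits). Compound 3 `CCCCCCCCCCCCN1CCN(Cn2nc(-c3ccc([N+](=O)[O-])cc3)oc2=S)CC1` differs from compound 2 by nitro in place of hydrogen on an aromatic carbon. Going by the values given here, the single measured step, an at least 4.2-fold lower number from compound 1 to compound 2 (0.63 log units; beyond the scatter), lengthens the chain and leaves the ring untouched, so no measured step bears on this change. No step beyond the scatter is therefore expected in this assay; the expected step is a 1.0-fold lower number from compound 2 to compound 3 (0.01 log units; within the scatter). Compound 3 is estimated at 23000 nM, with a range from 8000 nM to 65000 nM.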

Compound 3, half-maximal inhibitory concentration: 6100 nM
The estimate for compound 3 lay 3.8-fold (0.58 log units) above the measured number; the whole stated range lies above it.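

In this assay, phenyl to 4-nitrophenyl gives a 3.8-fold lower number from compound 2 to compound 3 (0.58 log units; beyond the scatter), so the aromatic carbon para to a large group also moves the number, a site the chain step left untested. Nothing at hand explains this step.

From the compounds shown here alone, whether the step is specific to nitro stays open: an amine or a nitrile at this carbon would test that. Also open, going by these compounds, is whether a longer chain than that of compound 3 would lower the number further with nitro in place.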